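From methyl to methoxy on the shared core

The source may report more compounds than this note shows. Statements on the series, on what has been measured and on what is new or still open speak of the compounds shown alone.

Compound 1 `Cc1ccc2c(c1)c(C1CCN(CCN3CCNC3=O)CC1)cn2-c1ccc(F)cc1` gives 0.0083 umol/kg
Compound 2 `O=C1NCCN1CCCN1CCC(c2cn(-c3ccc(F)cc3)c3ccc(Cl)cc23)CC1` gives 1.8 umol/kg
Compound 3 `Fc1ccc(-n2cc(C3=CCNCC3)c3cc(C(F)(F)F)ccc32)cc1` gives > 0.86 umol/kg

In a functional assay on the whole organism for inhibition, with Rattus norvegicus as the target (a lower number here means that less compound is needed, a higher number that more compound is needed for the effect), compound 1 holds the lowest of the two true numbers, well beyond the scatter from compound 2. The figure for compound 3 (> 0.86 umol/kg) is a limit and not a number. Compound 4 `COc1ccc2c(c1)c(C1CCN(CCN3CCNC3=O)CC1)cn2-c1ccc(F)cc1` keeps the core of compound 1 and carries methoxy in place of methyl on an aromatic carbon. Within the data shown here, no measured pair here differs in one place alone, so nothing shows directly how such a change acts in this assay. A small rise in the number, not far beyond the scatter, is expected, and the estimated 2.4-fold higher number from compound 1 to compound 4 (0.38 log units; beyond the scatter) stays modest. For compound 4 the expected value is 0.02 umol/kg (estimated range 0.004 umol/kg to 0.15 umol/kg).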

Compound 4, dose for half-maximal effect: 0.77 umol/kg
Beside the measured number, compound 4's estimate is 39-fold (1.59 log units) below it; the measured number lies above the stated range.
By their numbers in this assay, from the lowest: compound 1; then compound 4; then compound 2.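

Among these compounds, on the shared core, methoxy in place of methyl on an aromatic carbon gives a 93-fold higher number from compound 1 to compound 4 (1.97 log units; beyond the scatter) in this assay, the only step here that differs in one place. So this position is highly sensitive to this exchange, although the values shown give no cause for the step. Compound 3 holds a limit and not a number: the limit of > 0.86 umol/kg in this assay, at which 1 of the 4 values shown sits.

On these data alone, whether a hydroxyl or an ethyl group at this position would give a number nearer that of compound 1 or that of compound 4 remains open.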